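A tert-butoxycarbonyl group on compound 1

A few compounds are considered here, and "the series" means these few. Any claim that something is new, unique, unknown or untested is made for them only; others in the source may bear on it.

Among the compounds with values here, in a functional assay on HCT-116 cells (Homo sapiens) for inhibition, read by CCK-8 assay, with a stated time of 48 h (on this read-out higher numbers stand for weaker inhibition and lower numbers for stronger inhibition), compound 1 `COc1cc(-c2ccnc3cc(-c4c[nH]c5ccccc45)nn23)cc(OC)c1OC` gives 35 nM as the lower of the two numbers measured so far. Compound 2 `COc1cc(-c2ccnc3cc(-c4ccc(C(C)=O)cc4)nn23)cc(OC)c1OC` stands higher at 4390 nM and carries 4-acetylphenyl in place of 1H-indol-3-yl on an aromatic carbon. Compound 3 `COc1cc(-c2ccnc3cc(-c4cn(C(=O)OC(C)(C)C)c5ccccc45)nn23)cc(OC)c1OC` is still unmeasured. It differs from compound 1 by tert-butoxycarbonyl in place of hydrogen on an aromatic nitrogen in that tert-butoxycarbonyl stands in place of hydrogen on an aromatic nitrogen, in a five-membered aromatic ring with 1 nitrogen that is part of a fused or bridged system of two rings. Within the data shown here, only one measured step bears on this, and only indirectly, namely a 130-fold higher number from compound 1 to compound 2 (2.10 log units; beyond the scatter) on losing the whole 1H-indol-3-yl group, whereas compound 3 keeps that group and adds to its nitrogen. Among the measured compounds shown here, no measured compound shows what a change at this nitrogen does. A rise in this assay is nevertheless expected, smaller than that large step. The estimate is a 5.7-fold higher number from compound 1 to compound 3 (0.76 log units; beyond the scatter) as an expected rise. For compound 3 the expected value is 200 nM with a range from 40 nM to 1500 nM on this estimate.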

Compound 3, half-maximal inhibitory concentration: 5720 nM
For compound 3 the middle estimate is 29-fold (1.46 log units) below the measured one; the whole stated range lies below it.
By their numbers in this assay, from the lowest: compound 1; then compounds 2 and 3 (each within the scatter of the next).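

In this assay, the aromatic nitrogen of the five-membered ring proves to be a sensitive place: tert-butoxycarbonyl in place of hydrogen gives a 160-fold higher number from compound 1 to compound 3 (2.21 log units; beyond the scatter). The earlier step, a 130-fold higher number from compound 1 to compound 2 (2.10 log units; beyond the scatter), showed only what losing the whole 1H-indol-3-yl group does, whereas compound 3 keeps that group and still does not hold the low number of compound 1, so keeping the group is not enough on its own and what stands on its nitrogen matters as well. Nothing available accounts for the size of this step.

The compounds shown leave open whether the rise follows from the loss of the hydrogen on this nitrogen or from the tert-butoxycarbonyl group itself, since this is the only change at this nitrogen that they show. A methyl or an acetyl group on the same nitrogen, or a longer chain ending in an amine or a carboxylic acid, would show whether any group there gives such a step or only this one does.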